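The source may hold more compounds than are shown below. What is called first, only, known or untested is meant among the compounds shown, and "the series" means these compounds.

Measured so far in an ADME assay on cells (Hepatocyte, Homo sapiens) for metabolic stability, with a stated time of 30 min; a lower number here means that less of the compound is left, a higher number that more of the compound is left:

- compound 1 `CC(=O)NC1CCC(CN2CCN(c3cc(=O)c4cc(C(F)(F)F)cc([N+](=O)[O-])c4s3)CC2)CC1` gives 86.8%
- compound 2 `O=C(OC1CCC(CN2CCN(c3cc(=O)c4cc(C(F)(F)F)cc([N+](=O)[O-])c4s3)CC2)CC1)c1ccc(F)cc1` gives 3%
- compound 3 `O=C(NC1CCC(CN2CCN(c3cc(=O)c4cc(C(F)(F)F)cc([N+](=O)[O-])c4s3)CC2)CC1)c1ccccc1` gives 92.9%

Compound 3 has the highest of the three numbers, but compound 1 sits within the scatter of it (a number 6.1 percentage points higher from compound 1 to compound 3 (within the scatter)); only compound 2 stands apart (a number 89.9 percentage points higher from compound 2 to compound 3 (beyond the scatter), and likewise a number 83.8 percentage points lower from compound 1 to compound 2 (beyond the scatter)).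

The step to compound 4 `O=c1cc(N2CCN(CC3CCCCC3)CC2)sc2c([N+](=O)[O-])cc(C(F)(F)F)cc12` is hydrogen in place of benzamido on a saturated ring carbon. Among the compounds with values here, two measured steps touch the same saturated ring carbon. The swap of phenyl for methyl on the carbonyl carbon left the number unchanged within the scatter, whereas the exchange of the amide for the ester moved it by a large amount. Within the data shown here, no measured step removes the whole group and leaves a bare hydrogen, so the comparison is indirect. Among the measured compounds shown here, since both amides gave high numbers while the one compound without an amide, compound 2, gave a low one (3%), a drop beyond the scatter is expected, though of uncertain size; the expected step is a number 27.9 percentage points lower from compound 3 to compound 4 (beyond the scatter). For compound 4 the estimated value in this assay is 65%, with a range of 30% to 95%.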

Compound 4, percent of the compound remaining: 82.4%
Compound 4: middle estimate off by 17.4 percentage points, on the low side; the range from low to high includes it.
By their numbers in this assay, from the lowest: compound 2; then compounds 4, 1 and 3 (each within the scatter of the next, the first and the last beyond it).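

Hydrogen in place of benzamido costs only a modest amount in this assay (a number 10.5 percentage points lower from compound 3 to compound 4 (beyond the scatter)), and hydrogen in place of acetamido cannot be told apart from the amide (a number 4.4 percentage points lower from compound 1 to compound 4 (within the scatter)), so an amide on this saturated ring carbon is not required for a high number. Hydrogen in place of ((4-fluorophenyl)carbonyl)oxy gives a large rise (a number 79.4 percentage points higher from compound 2 to compound 4 (beyond the scatter)), which ties the low number of compound 2 to the presence of that group rather than to the absence of an amide. Nothing at hand bears on why that group stands apart.

Open, as far as these compounds go, is whether the low number of compound 2 follows the ester link or the fluorine on its phenyl ring; a plain benzoyloxy group would separate the two. Also open, from the compounds shown here alone, is how an amine or a carboxylic acid on the same carbon would read.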